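Thienopyrimidine ether pyridazinone amides: cytotoxicity notes

The source may report more compounds than this note shows. Statements on the series, on what has been measured and on what is new or still open speak of the compounds shown alone.

Measured so far:
compound 1 `CNC(=O)c1cc(Oc2ccc(NC(=O)c3nn(-c4ccccc4C(F)(F)F)c(=O)cc3C)cc2F)ccn1` — > 40000 nM
compound 2 `Cc1cc(=O)n(-c2cccc(F)c2)nc1C(=O)Nc1ccc(Oc2ncnc3ccsc23)c(F)c1` — 7810 nM
compound 3 `Cc1cc(=O)n(-c2ccccc2C(F)(F)F)nc1C(=O)Nc1ccc(Oc2ncnc3sccc23)c(F)c1` — 14700 nM

In a functional assay on HepG2 cells (Homo sapiens) for cytotoxicity, read by MTT assay, with a stated time of 72 h (a lower number here means a stronger inhibitor, a higher number a weaker inhibitor), compound 1 reaches only a limit, > 40000 nM, and no number. Among the measured compounds shown here, the one measured step, an at least 2.7-fold lower number from compound 1 to compound 3 (0.43 log units; beyond the scatter), rests on that limit (the limit of > 40000 nM in this assay, at which 1 of the 3 values shown sits). Compound 3 stands at 14700 nM, the highest of the two numbers given; its nearest neighbour is compound 2 at 7810 nM, and the two sit within the scatter of each other, so no order between them is claimed.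

Compound 4 `Cc1cc(=O)n(-c2cccc(F)c2)nc1C(=O)Nc1ccc(Oc2ncnc3sccc23)c(F)c1` is not yet measured. It differs from compound 3 by 3-fluorophenyl in place of 2-(trifluoromethyl)phenyl on an aromatic nitrogen. For the measured compounds named here, no measured step changes this group alone. Going by the values given here, compound 2 already carries the 3-fluorophenyl group on the shared core and gives a value within the scatter of compound 3, which is the only indirect guide.

The expected step is therefore a 1.5-fold lower number from compound 3 to compound 4 (0.17 log units; within the scatter), none beyond the scatter. Compound 4 is estimated at 10000 nM, with a range from 4000 nM to 30000 nM.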

Compound 4, half-maximal inhibitory concentration: 24500 nM
Beside the measured number, compound 4's estimate is 2.5-fold (0.39 log units) below it, and the stated range covers the measured number.
By their numbers in this assay, from the lowest: compounds 2, 3 and 4 (each within the scatter of the next, the first and the last beyond it). At a limit, above all of these: compound 1.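

In this assay, a 1.7-fold higher number from compound 3 to compound 4 (0.22 log units; within the scatter), so 3-fluorophenyl in place of 2-(trifluoromethyl)phenyl on the aromatic nitrogen, now read directly as a single change, separates the two compounds by no more than the scatter. The clearer difference lies elsewhere: a 3.1-fold higher number from compound 2 to compound 4 (0.50 log units; beyond the scatter), with 3-fluorophenyl held constant and only the group on the ether oxygen exchanged for one of the same heavy-atom composition. Nothing measured here gives a reason for either step.

Among the compounds shown here, only two fluorinated phenyl groups appear on the aromatic nitrogen, so the effect of a plain phenyl, a pyridyl ring or an alkyl chain carrying an amine at this position remains open. Also open, from the compounds shown here alone, is whether the difference between the two groups on the ether oxygen holds with 2-(trifluoromethyl)phenyl on the nitrogen.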